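The compounds below may be only part of what the source reports. "The series", "measured", "known", "first", "only" and "open" are said of these compounds alone.

In a functional assay on cells (Cancer cell lines, Homo sapiens) for inhibition (on this read-out lower numbers stand for stronger inhibition of growth and higher numbers for weaker inhibition of growth), two compounds have numbers so far:

Compound 1 (`N=C(N)N/N=C/c1c(-c2ccsc2)nc2sccn12`) gives 14800 nM
Compound 2 (`N=C(N)N/N=C/c1c(-c2cccs2)nc2sccn12`) gives 12300 nM

Compound 2 stands level with compound 1 on these numbers, so neither can be called the stronger inhibitor of growth. The next compound to look at is compound 3 (`Cc1cc(-c2nc3sccn3c2/C=N/NC(=N)N)c(C)s1`), which keeps the shared core. Its change from compound 2 is 2,5-dimethylthiophen-3-yl in place of thiophen-2-yl on an aromatic carbon and it sits on an aromatic carbon of a five-membered aromatic ring with 2 nitrogen.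

Among the measured compounds shown here, only one measured step bears on this. It is a 1.2-fold lower number from compound 1 to compound 2 (0.08 log units; within the scatter) and so exchanging one thiophene attachment for the other made no difference that can be told from scatter. For the measured compounds named here, no measured compound carries methyl groups on this ring, so the data offer no direct guide to their effect. A modest shift toward a lower number in this assay is therefore only a tentative expectation, and no shift at all would be no surprise. The expected step is a 2.1-fold lower number from compound 2 to compound 3 (0.31 log units; beyond the scatter) and it remains uncertain. The estimated value for compound 3 is 6000 nM within an expected range from 2000 nM to 15000 nM on this read-out.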

Compound 3, concentration for 50% growth inhibition: 13800 nM
For compound 3 the middle estimate is 2.3-fold (0.36 log units) below the measured one, within the range that was stated.
By their numbers in this assay, from the lowest: compounds 2, 3 and 1 (each within the scatter of the next).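

In this assay, swapping either plain thiophene for 2,5-dimethylthiophen-3-yl leaves the numbers level, with a 1.1-fold higher number from compound 2 to compound 3 (0.05 log units; within the scatter) and a 1.1-fold lower number from compound 1 to compound 3 (0.03 log units; within the scatter). The second of these steps is the cleaner comparison, as the ring is attached through the same carbon in both compounds and the two methyl groups are the visible difference. The earlier step compared only two unsubstituted thiophenes, whereas these results show that this aromatic carbon, on the five-membered aromatic ring with 2 nitrogen, can carry a group of 7 heavy atoms instead of 5 with no difference that can be told from scatter, though nothing available explains this.

From the compounds shown here alone, all three compounds carry a thiophene here, so it remains open whether the numbers would stay level with a different kind of group, such as a phenyl ring, an amine or a carboxylic acid. It is also unknown whether a longer chain at this position could move the number beyond the scatter in either direction.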